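Removing One Methoxy Group From the Dimethoxyphenyl Chalcone

This account rests on a few compounds, and the source may have more. Where it says the series, first, only, none or still open, it means among the compounds named here.

Compound 1, `COc1cc(/C=C/C(=O)/C=C/c2ccccc2)ccc1OCc1cn(CCCOc2cc(=O)oc3ccccc23)nn1`, gives 43% in a functional assay on COLO 205 cells (Homo sapiens) for inhibition, read by sulforhodamine B assay, with a stated time of 48 h, tested at 50 uM; a lower number here means less inhibition of growth, a higher number more inhibition of growth at the concentration tested.
Compound 2, `COc1ccccc1/C=C/C(=O)/C=C/c1ccc(OCc2cn(CCCOc3cc(=O)oc4ccccc34)nn2)c(OC)c1`, gives 57% in this assay.
Compound 3, `COc1ccc(/C=C/C(=O)/C=C/c2ccc(OCc3cn(CCCOc4cc(=O)oc5ccccc45)nn3)c(OC)c2)cc1OC`, gives 65% in this assay.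

Compound 3 holds the highest of the three numbers, but its gap to compound 2 lies within the scatter, so the two cannot be ordered; only compound 1 sits clearly lower.

Compound 4, `COc1ccc(/C=C/C(=O)/C=C/c2ccc(OCc3cn(CCCOc4cc(=O)oc5ccccc45)nn3)c(OC)c2)cc1`, differs from compound 3 in one place: hydrogen in place of methoxy on an aromatic carbon. Among the compounds with values here, two measured steps bear on this. The gain a number 22 percentage points higher from compound 1 to compound 3 (beyond the scatter) came from putting two methoxy groups onto a bare phenyl, and compound 4 gives one of them back. The change a number 8 percentage points higher from compound 2 to compound 3 (within the scatter), which moved one methoxy and added another, stayed within the scatter. Taking one methoxy away is therefore expected to cost part of the gain seen for compound 3, a modest drop rather than a fall to the level of compound 1.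

Compound 4 is estimated at 55%, with a range of 42% to 68%, which means an expected step of a number 10 percentage points lower from compound 3 to compound 4 (within the scatter).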

Compound 4, percent growth inhibition at one concentration: 53%
For compound 4 the middle estimate is 2 percentage points above the measured one; low and high end bracket the measured number.
By their numbers in this assay, from the lowest: compounds 1, 4, 2 and 3 (each within the scatter of the next, the first and the last beyond it).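

The change from 3,4-dimethoxyphenyl to 4-methoxyphenyl shows that this one methoxy group, ortho to the methoxy group that remains, counts on its own: the result is a number 12 percentage points lower from compound 3 to compound 4 (beyond the scatter). Within the data shown here, the same exchange of hydrogen and methoxy has now been seen twice, with steps of similar size on two different cores: the same change on two cores in this assay, a number 14 percentage points higher (beyond the scatter) from compound 1 to compound 2 and a number 12 percentage points higher (beyond the scatter) from compound 4 to compound 3, 2 percentage points apart, within the scatter of two such steps Against any general gain from a methoxy group stands a number 10 percentage points higher from compound 1 to compound 4 (within the scatter), and moving the single methoxy group gives a number 4 percentage points lower from compound 2 to compound 4 (within the scatter), so neither of these two steps can be read as a real change.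

Open, on these data alone, is whether another group at this place, such as a hydroxyl, an amine or a chlorine atom, would match methoxy. Also open, as far as these compounds go, is how a longer chain on this oxygen, such as ethoxy, would read in this assay.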